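Phenyl in place of thiophen-2-yl: expected outcome

The source may hold more compounds than are shown below. What is called first, only, known or untested is meant among the compounds shown, and "the series" means these compounds.

Compound 1 `CCCSc1nc(N/N=C/c2cccs2)c2nnn(Cc3ccccc3)c2n1` is tested in a functional assay on MCF7 cells (Homo sapiens) for antiproliferative activity, read by MTT assay, with a stated time of 72 h; on this read-out lower numbers stand for stronger inhibition and higher numbers for weaker inhibition. In this assay compound 1 gives > 64000 nM, which is a limit of the assay and not a number. Compound 2 `C#CCSc1nc(N/N=C/c2ccc(N(C)C)cc2)c2nnn(Cc3ccccc3)c2n1` in this assay gives > 64000 nM, likewise a limit. Compound 1 therefore sits at the limit of > 64000 nM in this assay, at which 2 of the 2 values shown sit, with no numbered value in the series to set it against. Compound 3 `CCCSc1nc(N/N=C/c2ccccc2)c2nnn(Cc3ccccc3)c2n1` differs from compound 1 by phenyl in place of thiophen-2-yl on a carbon with a double bond to nitrogen. For the measured compounds named here, no measured pair carries this change; with both known values at the limit, the step is expected to be none beyond the scatter, a step that the limit leaves unreadable from compound 1 to compound 3. Compound 3 is expected to give 100000 nM, within 30000 nM to 300000 nM, most probably again reported as a limit.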

Compound 3, half-maximal inhibitory concentration: > 64000 nM
Compound 3: a limit, no number (the forecaster's own chance of this, stated with the estimate: 85%); the middle value does not contradict the limit.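

No step can be read between compound 1 and compound 3 in this assay because neither gives a number: the limit of > 64000 nM in this assay, at which 3 of the 3 values shown sit. The compounds shown leave open whether phenyl or thiophen-2-yl changes antiproliferative activity at all.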